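The compounds below may be only part of what the source reports. "The series", "measured", "known", "first", "only" and "open" are said of these compounds alone.

In a functional assay on A549 cells (Homo sapiens) for antiproliferative activity, read by MTT assay, with a stated time of 72 h (a lower number here means a stronger inhibitor, a higher number a weaker inhibitor), compound 3 `C=CC(=O)Nc1cccc(Oc2nc(Nc3cccc(OC)c3)nc3c2CSCC3)c1` gives 10100 nM, the lowest number shown, and compound 2 `C=C(C)C(=O)Nc1cccc(Oc2nc(Nc3ccn(C)n3)nc3c2CSCC3)c1` gives 46900 nM. Compound 1 `C=C(F)C(=O)Nc1cccc(Oc2nc(Nc3ccn(C)n3)nc3c2CSCC3)c1` gives > 50000 nM, which is a limit and not a number. Compound 4 `COc1cccc(Nc2nc3c(c(Oc4cccc(NC(=O)C=C(C)C)c4)n2)CSCC3)c1` differs from compound 3 by 2-methylprop-1-en-1-yl in place of vinyl on a carbonyl carbon. Among the compounds with values here, the only measured step on this chain, an at least 1.0-fold lower number from compound 1 to compound 2 (0.02 log units; that floor lies within the scatter), stays within the scatter and exchanges a different group, so it is a weak guide. Compounds 1 and 2 also differ from compound 3 elsewhere in the structure. Compound 2, with a substituted chain, still sits high at 46900 nM, so a moderate rise is expected, a 2.5-fold higher number from compound 3 to compound 4 (0.39 log units; beyond the scatter). Compound 4 is estimated at 25000 nM, with an expected range of 9000 nM to 50000 nM.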

Compound 4, half-maximal inhibitory concentration: 19800 nM
Estimate against measurement, compound 4: 1.3-fold (0.10 log units) above; low and high end bracket the measured number.
By their numbers in this assay, from the lowest: compounds 3 and 4 (each within the scatter of the next); then compound 2. At a limit, above all of these: compound 1.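

In this assay, within the data shown here, the step at this carbonyl carbon, a 2.0-fold higher number from compound 3 to compound 4 (0.29 log units; within the scatter), gives the first reading of a change on this chain with the rest of the structure held the same. Replacing vinyl with 2-methylprop-1-en-1-yl therefore leaves the two numbers indistinguishable, whereas the earlier step on this chain rested on a limit. Nothing shown gives a cause for this result.

Going by these compounds, it remains open how an amine on the chain, such as a dimethylaminomethyl group on the vinyl, would read. On these data alone, whether the same exchange behaves alike on the core of compound 2 also remains open.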